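The Step from Compound 3 to Compound 4

The source may report more compounds than this note shows. Statements on the series, on what has been measured and on what is new or still open speak of the compounds shown alone.

In an assay on SW1353 cells (Homo sapiens) for inhibition, read by a luciferase reporter, with stated times of 30 min and 8 h (on this read-out lower numbers stand for stronger inhibition and higher numbers for weaker inhibition), compound 3 (`O=c1sc2ccccc2n1CCCCCN1CCN(CCn2c(=O)sc3ccccc32)CC1`) gives 1710 nM. That lies within the scatter of compound 1 (`O=c1oc2ccccc2n1CCCCCN1CCN(CCCCCn2c(=O)oc3ccccc32)CC1`), at 3430 nM, while compound 2 (`O=c1sc2ccccc2n1CCCCCCN1CCN(CCCCCCn2c(=O)sc3ccccc32)CC1`), at 410 nM, has a lower number, beyond the scatter. Compound 4 (`O=c1sc2ccccc2n1CCCCCCN1CCN(CCn2c(=O)sc3ccccc32)CC1`) differs from compound 3 by a single change: a group of 11 heavy atoms (8 carbon, 1 nitrogen, 1 oxygen, 1 sulfur; one five-membered aromatic ring with 2 hetero atoms, one six-membered aromatic ring of carbon only) in place of a group of 10 heavy atoms (7 carbon, 1 nitrogen, 1 oxygen, 1 sulfur; one five-membered aromatic ring with 2 hetero atoms, one six-membered aromatic ring of carbon only), on a saturated chain carbon, five bonds along the chain from an amine nitrogen in a ring. Among the compounds with values here, no measured pair isolates such a change in this assay. Within the data shown here, the only hint comes from compound 2 at 410 nM, so a modest move towards a lower number is expected, possibly no larger than the scatter. The estimated step is a 1.7-fold lower number from compound 3 to compound 4 (0.23 log units; within the scatter). For compound 4 the expected value is 1000 nM, with an estimated range of 400 nM to 2500 nM.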

Compound 4, half-maximal inhibitory concentration: 2950 nM
Beside the measured number, compound 4's estimate is 3.0-fold (0.47 log units) below it; the measured number lies above the stated range.
By their numbers in this assay, from the lowest: compound 2; then compounds 3, 4 and 1 (each within the scatter of the next).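

In this assay, the group of 11 heavy atoms in place of the group of 10 heavy atoms, on a saturated chain carbon, five bonds along the chain from an amine nitrogen in a ring, gives a 1.7-fold higher number from compound 3 to compound 4 (0.24 log units; within the scatter). This is the only pair shown that isolates a change at this position, and the extra carbon leaves the read-out within the scatter. Nothing available explains this result.

As far as these compounds go, whether a longer chain at this place would go beyond the scatter stays open. So does the effect of an amine or a carboxylic acid on this chain.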